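The source may hold more compounds than are shown below. What is called first, only, known or untested is meant among the compounds shown, and "the series" means these compounds.

In a functional assay on MCF7 cells (Homo sapiens) for antiproliferative activity, read by MTT assay, with a stated time of 72 h (on this read-out lower numbers stand for stronger inhibition and higher numbers for weaker inhibition), compound 2 `COc1cccc(N2C(=O)COc3ccc(-c4cccc(NS(=O)(=O)c5ccc(F)cc5)c4)cc32)c1` reads > 40000 nM, which is a limit of the assay and not a number. Compound 1 `COc1cccc(N2C(=O)COc3ccc(-c4cnc(Cl)c(NS(=O)(=O)c5ccc(F)cc5)c4)cc32)c1` reads > 40000 nM, which is also a limit. Compound 3 `Cc1ccc(N2C(=O)COc3ccc(-c4cnc(Cl)c(NS(=O)(=O)c5ccc(F)cc5)c4)cc32)cc1` gives a measured number, 32600 nM. These three measurements rest largely on (the limit of > 40000 nM in this assay, at which 2 of the 3 values shown sit).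

The change in question leads from compound 2 to compound 4 `COc1ccc(N2C(=O)COc3ccc(-c4cccc(NS(=O)(=O)c5ccc(F)cc5)c4)cc32)cc1`: 4-methoxyphenyl in place of 3-methoxyphenyl on an amide-type nitrogen in a ring. In words, this is 4-methoxyphenyl in place of 3-methoxyphenyl on an amide-type nitrogen in a ring. For the measured compounds named here, only one measured step touches that place, an at least 1.2-fold lower number from compound 1 to compound 3 (0.08 log units; that floor lies within the scatter), where 4-methylphenyl replaces 3-methoxyphenyl on the core of compound 1 rather than the core of compound 2. That step is known only as a floor, so it offers no firm direction. No step beyond the scatter is therefore expected in this assay, and the estimated size is a number no higher from compound 2 to compound 4 (the limit leaves the size open). Compound 4 is expected at 40000 nM, with an estimated range from 20000 nM to 80000 nM.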

Compound 4, half-maximal inhibitory concentration: 32400 nM
Beside the measured number, compound 4's estimate is 1.2-fold (0.09 log units) above it, within the range that was stated.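

In this assay, 4-methoxyphenyl in place of 3-methoxyphenyl on the amide-type nitrogen gives an at least 1.2-fold lower number from compound 2 to compound 4 (0.09 log units; that floor lies within the scatter), so this shift of the methoxy group shows no step beyond the scatter on the core of compound 2. Compound 4 gives 32400 nM, the only measured number on this core among the compounds shown. The true size of the step stays open because one end of it is a limit of the assay and not a number: the limit of > 40000 nM in this assay, at which 2 of the 4 values shown sit.

From the compounds shown here alone, it remains open whether 4-methoxyphenyl would read the same way on the core of compound 1. Going by these compounds, it is also open whether a different group on this nitrogen, such as an aminophenyl, a carboxyphenyl or a longer alkyl chain, would bring the number down beyond the scatter.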